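Chloro Enters the Cyclopentyl Sulfone of Compound 1

A few compounds are considered here, and "the series" means these few. Any claim that something is new, unique, unknown or untested is made for them only; others in the source may bear on it.

Compound 1 `O=S(=O)(c1ccc(O)c2ncccc12)C1CCCC1` is the starting point. In an ADME assay on the whole organism for metabolic stability, with Rattus norvegicus as the target (a lower number here means that the compound disappears faster, a higher number that the compound lasts longer), compound 1 gives 0.18 h, the lowest of the three numbers at hand. Compound 3 `Cc1ccc(S(=O)(=O)c2cc(F)c(O)c3ncccc23)cc1` gives 0.26 h, which lies within the scatter of compound 1, so no order between the two can be claimed. Compound 2 `O=S(=O)(c1ccc(C(F)(F)F)cc1)c1cc(F)c(O)c2ncccc12` gives 3.5 h, far higher than compound 1. Among the compounds with values here, the only measured step, a 13-fold lower number from compound 2 to compound 3 (1.13 log units; beyond the scatter), concerns a group elsewhere in the molecule and does not touch the place altered here.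

Compound 4 `O=S(=O)(c1cc(Cl)c(O)c2ncccc12)C1CCCC1` differs from compound 1 by chloro in place of hydrogen on an aromatic carbon. Within the data shown here, no measured pair tests this change, so the expectation rests on compound 1 alone, with the value of compound 3 as a loose guide. The step from compound 1 to compound 4 is expected to be a 1.7-fold higher number from compound 1 to compound 4 (0.22 log units; within the scatter), a small move upward that may well fall within the scatter. Compound 4 is expected to give 0.3 h, within a range from 0.12 h to 0.8 h.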

Compound 4, half-life: 11 h
Estimate against measurement, compound 4: 37-fold (1.56 log units) below; the whole stated range lies below it.
By their numbers in this assay, from the lowest: compounds 1 and 3 (each within the scatter of the next); then compound 2; then compound 4.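

Chloro in place of hydrogen on this aromatic carbon, ortho to the hydroxy group, brings a 61-fold higher number from compound 1 to compound 4 (1.79 log units; beyond the scatter) in this assay, so a change of a single heavy atom at this place can decide how long the compound lasts. Within the data shown here, the earlier compounds offered no pair that tested this position, and their one measured step, a 13-fold lower number from compound 2 to compound 3 (1.13 log units; beyond the scatter), concerned a group elsewhere in the molecule. Nothing measured here explains why chloro has so large an effect at this place.

From the compounds shown here alone, it remains open whether other groups at this carbon, such as bromo, methoxy or an amine, would give a similar step or a much smaller one. Going by these compounds, it is also open whether chloro would have the same effect if the cyclopentyl group on the sulfone were replaced by another group.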